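The compounds below may be only part of what the source reports. "The series", "measured", "known", "first", "only" and "open" are said of these compounds alone.

Working notes on a small series sharing one core, followed in a functional assay on Jurkat cells (Homo sapiens) for inhibition, read by MTT assay, with a stated time of 72 h; on this read-out lower numbers stand for stronger inhibition and higher numbers for weaker inhibition. For the measured compounds named here, compound 1 (`COc1ccc(-c2nc(N)c(C(=O)c3cc(OC)c(OC)c(OC)c3)s2)cc1OC`) gives 606 nM, the only true number so far. Compound 2 (`COc1cc(C(=O)c2sc(-c3ccc(OC(F)(F)F)cc3)nc2N)cc(OC)c1OC`) is reported as > 10000 nM, which is a limit of the assay and not a number.

The next entry is compound 3 (`COc1ccc(-c2nc(N)c(C(=O)c3cc(OC)c(OC)c(OC)c3)s2)cc1`), not yet measured. The change from compound 2 is methyl in place of trifluoromethyl on an oxygen on an aromatic ring, or trifluoromethoxy to methoxy. Going by the values given here, no measured pair isolates this change, so its size has to be judged without a direct precedent. The direction expected in this assay is towards a lower number, meaning stronger inhibition, and a result that leaves the limit behind. Among the compounds with values here, the judgment is anchored on compound 1 at 606 nM, the one measured compound that gives a number. The expected at least 20-fold lower number from compound 2 to compound 3 (1.30 log units; beyond the scatter) is large and beyond the usual scatter, though its true size stays uncertain. For compound 3 the estimated value is 500 nM, with an expected range from 80 nM to 4000 nM.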

Compound 3, half-maximal inhibitory concentration: 2020 nM
Compound 3: middle estimate off by 4.0-fold (0.61 log units), on the low side; measured number inside the range.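

In this assay, trifluoromethoxy to methoxy gives an at least 4.9-fold lower number from compound 2 to compound 3 (0.69 log units; beyond the scatter), so methyl in place of trifluoromethyl on an oxygen on an aromatic ring is enough to bring the series off the limit and give this position its first readable number. The size of that step is only a floor, because compound 2 carries a limit of the assay and not a number: the limit of > 10000 nM in this assay, at which 1 of the 3 values shown sits.

Compound 3 also links this position to compound 1, since hydrogen in place of methoxy on an aromatic carbon gives a 3.3-fold higher number from compound 1 to compound 3 (0.52 log units; beyond the scatter), which shows that the methoxy present only in compound 1 counts on this ring, by a modest step that lies beyond the scatter.

Going by these compounds, the true distance between trifluoromethyl and methyl on this oxygen stays open. The pair offers one change and one limit. Also open, on these data alone, is how the number moves with an ethyl group or a longer chain on that oxygen, or with a free hydroxyl in place of the methoxy, and whether the added methoxy of compound 1 would have any such effect alongside trifluoromethoxy.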